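A few compounds are considered here, and "the series" means these few. Any claim that something is new, unique, unknown or untested is made for them only; others in the source may bear on it.

Measured in a toxicity assay on HEK-293T cells (Homo sapiens) for cytotoxicity, read by MTT assay, with a stated time of 72 h (on this read-out higher numbers stand for weaker inhibition and lower numbers for stronger inhibition), so far:
- compound 1, `O=C1c2c[n+]([O-])c3ccccc3c2C(=O)c2c1c1ccccc1n2CCCCn1ccnc1`, gives 280 nM
- compound 2, `O=C1c2c[n+]([O-])c3ccccc3c2C(=O)c2c1c1ccccc1n2Cc1cn([C@H]2C[C@H](O)[C@@H](CO)O2)nn1`, gives 3600 nM

Compound 1 holds the lowest of the two numbers in this assay; compound 2 sits well above it, beyond the scatter of repeat measurements, so of these two, compound 1 is the stronger inhibitor of cell viability. Among the compounds with values here, no single-point step between measured compounds is available, so nothing is known about what removing or changing the substituent on the aromatic nitrogen does to the read-out.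

Compound 3, `O=C1c2c[n+]([O-])c3ccccc3c2C(=O)c2[nH]c3ccccc3c21`, is the unsubstituted core. It differs from compound 1 as follows: hydrogen in place of 4-(1H-imidazol-1-yl)butyl on an aromatic nitrogen

Within the data shown here, with no comparable step to lean on, a modest loss of potency in this assay is expected, in the direction of a higher number, but not far beyond the scatter. Compound 3 is therefore estimated at 600 nM, in the range 150 nM to 3000 nM. The expected step is a 2.1-fold higher number from compound 1 to compound 3 (0.33 log units; beyond the scatter).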

Compound 3, half-maximal inhibitory concentration: 890 nM
The estimate for compound 3 lay 1.5-fold (0.17 log units) below the measured number; low and high end bracket the measured number.
By their numbers in this assay, from the lowest: compound 1; then compound 3; then compound 2.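

In this assay, the aromatic nitrogen now has its first single-place comparison: replacing 4-(1H-imidazol-1-yl)butyl with hydrogen gives a 3.2-fold higher number from compound 1 to compound 3 (0.50 log units; beyond the scatter), a modest step that lies beyond the scatter. The substituent therefore contributes to the read-out at this position, but it is not required for activity, since the unsubstituted core of compound 3 still gives 890 nM in this cytotoxicity read-out. No measurement shown here explains the size or direction of this step.

The compounds shown do not separate the contribution of the four-carbon chain from that of the imidazole ring, a question that a plain butyl group or a shorter chain ending in imidazole could address. On these data alone, it also remains open how a terminal amine or carboxylic acid on the same nitrogen would compare with the imidazole.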